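Trading a piperazinylmethyl group for fluoro in an oxadiazole series

A few compounds are considered here, and "the series" means these few. Any claim that something is new, unique, unknown or untested is made for them only; others in the source may bear on it.

Compound 3 `Cc1ccc(-c2nnc(-c3ccc(CN4CCN(C)CC4)c(C(F)(F)F)c3)o2)cc1Nc1nccc(-c2cccnc2)n1` gives 580 nM in a functional assay on KG-1a cells (Homo sapiens) for inhibition, read by MTT assay, with a stated time of 72 h (on this read-out lower numbers stand for stronger inhibition and higher numbers for weaker inhibition), the lowest of the three numbers shown. Compound 2 `Cc1ccc(-c2nnc(-c3ccc(CN4CCN(C)CC4)cc3)o2)cc1Nc1nccc(-c2cccnc2)n1` gives 1780 nM in this assay, and compound 1 `Cc1ccc(-c2cn(-c3ccc(CN4CCN(C)CC4)cc3)nn2)cc1Nc1nccc(-c2cccnc2)n1` gives 6160 nM. Among the compounds with values here, the one step between neighbouring compounds, a 3.1-fold lower number from compound 2 to compound 3 (0.49 log units; beyond the scatter), concerns a different position and so does not bear on the change now at hand. Compound 4 `Cc1ccc(-c2nnc(-c3ccc(F)c(C(F)(F)F)c3)o2)cc1Nc1nccc(-c2cccnc2)n1` differs from compound 3 by fluoro in place of (4-methylpiperazin-1-yl)methyl on an aromatic carbon. Within the data shown here, no measured pair shows this exchange, so nothing here fixes its direction. Compound 4 is expected to come out somewhat weaker, a step of a 2.1-fold higher number from compound 3 to compound 4 (0.32 log units; beyond the scatter). For compound 4 the estimate is 1200 nM, with a range from 300 nM to 5000 nM.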

Compound 4, half-maximal inhibitory concentration: > 30000 nM
Compound 4 gave a limit, no number; the forecaster's own chance of this, stated with the estimate: 5%; middle value at least 25-fold (1.39 log units) from the limit.
By their numbers in this assay, from the lowest: compound 3; then compound 2; then compound 1. At a limit, above all of these: compound 4.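

All three earlier compounds carry (4-methylpiperazin-1-yl)methyl on this aromatic carbon, so they could not show what depends on it; replacing it with fluoro, ortho to a trifluoromethyl group, gives an at least 51-fold higher number from compound 3 to compound 4 (1.71 log units; beyond the scatter). Compound 4 gives a limit, not a number: the limit of > 30000 nM in this assay, at which 1 of the 4 values shown sits. In this oxadiazole pair, the trifluoromethyl group alone does not keep a measurable value in this assay once the piperazinylmethyl group has gone.

From the compounds shown here alone, what remains open is whether the whole group is needed or a simple amine such as dimethylaminomethyl would serve. A morpholinylmethyl group at this carbon would test the same question.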